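The source may hold more compounds than are shown below. What is called first, only, known or untested is meant among the compounds shown, and "the series" means these compounds.

Measured compounds in a functional assay on A549 cells (Homo sapiens) for antiproliferative activity, read by MTT assay, with a stated time of 72 h; a higher number here means a weaker inhibitor, a lower number a stronger inhibitor:
- Compound 1 `O=C1O[C@H]([C@@H](O)Cn2cc(-c3cccc(O)c3)nn2)C(OCc2ccccc2)=C1OCc1ccccc1` gives 59900 nM as a measured number
- Compound 2 `COc1ccccc1-c1cn(C[C@H](O)[C@H]2OC(=O)C(OCc3ccccc3)=C2OCc2ccccc2)nn1` gives > 100000 nM as a limit
- Compound 3 `O=C1O/C(=C\Cn2cc(-c3cc(C(F)(F)F)cc(C(F)(F)F)c3)nn2)C(OCc2ccccc2)=C1OCc1ccccc1` gives > 100000 nM as a limit

Compound 2 has no number of its own, and its > 100000 nM is only a limit of the assay. Compound 2 and compound 3 both stand at the limit of > 100000 nM in this assay, at which 2 of the 3 values shown sit, in this set. The next compound is compound 4 `CC(C)(C)c1cn(C[C@H](O)[C@H]2OC(=O)C(OCc3ccccc3)=C2OCc2ccccc2)nn1`, and the change from compound 2 is this one (tert-butyl in place of 2-methoxyphenyl on an aromatic carbon). The aromatic ring of the 2-methoxyphenyl group leaves with it, and no ring enters.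

Within the data shown here, one measured step bears on this place, namely an at least 1.6-fold higher number from compound 1 to compound 2 (0.22 log units; that floor lies within the scatter) as seen in this assay when one aromatic group replaces another. Among the measured compounds shown here, no compound measured so far carries a group without a ring here, so the data give no direction for the change. No step beyond the scatter is therefore expected. For the measured compounds named here, compound 1 at 59900 nM is the only number available, and it gives no ground to expect a much stronger inhibitor. The expected change is a number no higher from compound 2 to compound 4 (the limit leaves the size open) in size. For compound 4 the estimated value is 100000 nM in this assay, with an expected range from 40000 nM to 250000 nM as its ends.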

Compound 4, half-maximal inhibitory concentration: 34000 nM
Compound 4: the middle estimate sits 2.9-fold (0.47 log units) above what was measured; measured number below the stated range.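

In this assay, a group without a ring on this aromatic carbon of the five-membered aromatic ring gives a measured number, and tert-butyl in place of 2-methoxyphenyl gives an at least 2.9-fold lower number from compound 2 to compound 4 (0.46 log units; beyond the scatter). An aromatic ring at this place is therefore not required for measurable activity among the compounds shown, and the replacement of 3-hydroxyphenyl by tert-butyl gives a 1.8-fold lower number from compound 1 to compound 4 (0.25 log units; within the scatter), so the ringless group and the hydroxylated aromatic group cannot be told apart here. The step from the 2-methoxyphenyl compound gives only a floor and leaves its full size open, since compound 2 has no number of its own: the limit of > 100000 nM in this assay, at which 2 of the 4 values shown sit.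

The compounds shown leave open whether this tolerance extends to other groups without a ring, such as a methyl group, a longer alkyl chain, a primary amine or a carboxylic acid. They also leave open whether any group at this place can bring the number far below that of compound 4, which gives 34000 nM.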